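The compounds below may be only part of what the source reports. "The series", "measured", "known", "first", "only" and "open" are said of these compounds alone.

Measured so far in an assay on HEK-293T cells for inhibition of diacylglycerol lipase-alpha (Homo sapiens), read by colorimetric assay; a higher number here means a weaker inhibitor, a lower number a stronger inhibitor:
- compound 1 `O=C(CCCCCCc1ccccc1)c1nnn[nH]1` gives > 10000 nM; > 10000 nM (2 entries).
- compound 2 `O=Cc1coc(C(=O)CCCCCCc2ccccc2)n1` gives 1510 nM.
- compound 3 `O=C(CCCCCCc1ccccc1)c1nc(Br)co1` gives > 10000 nM.

The value of compound 3 is a limit of the assay, not a number, so its true potency is known only to lie somewhere beyond (the limit of > 10000 nM in this assay, at which 1 of the 3 values shown sits). The value of compound 1 is likewise only a limit. For the measured compounds named here, compound 2 is the only one of the three with a measured number, and the single step that touches compound 3 is an at least 6.6-fold higher number from compound 2 to compound 3 (0.82 log units; beyond the scatter), which moved the potency out of the measurable range.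

Compound 4 `O=C(CCCCCCc1ccccc1)c1ncno1` differs from compound 3 in one place: 1,2,4-oxadiazol-5-yl in place of 4-bromo-1,3-oxazol-2-yl on a carbonyl carbon. Going by the values given here, no measured step covers this swap of one small heterocycle for another. What can be said is that compound 1, which also carries a plain heterocycle on the carbonyl, gives no number either. Taken together, a step beyond the scatter in this assay is not expected, and the estimated step from compound 3 to compound 4 is a step that the limit leaves unreadable from compound 3 to compound 4. Compound 4 is estimated at 15000 nM, with a range from 3000 nM to 60000 nM.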

Compound 4, half-maximal inhibitory concentration: > 10000 nM
Compound 4: only a limit was reported (the forecaster's own chance of this, stated with the estimate: 65%); the middle value does not contradict the limit.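

Compound 4 gives > 10000 nM in this assay, which is a limit of the assay and not a number. Measured against compound 2, the swap of 4-formyl-1,3-oxazol-2-yl for 1,2,4-oxadiazol-5-yl on the carbonyl carbon gives an at least 6.6-fold higher number from compound 2 to compound 4 (0.82 log units; beyond the scatter), so a second replacement for that group, after the 4-bromo-1,3-oxazol-2-yl of compound 3, also loses the measurable potency of compound 2. The step from compound 3 to compound 4 cannot be read, as both compounds stand at one ceiling: the limit of > 10000 nM in this assay, at which 2 of the 4 values shown sit.

From the compounds shown here alone, how weak compound 4 really is stays open, as does whether the formyl group itself carries the measured potency of compound 2. A 1,3-oxazol-2-yl bearing a carboxylic acid or an amide in place of the formyl would speak to that.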